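The source may hold more compounds than are shown below. What is called first, only, known or untested is meant among the compounds shown, and "the series" means these compounds.

Compound 1 `Nc1ccccc1S(=O)(=O)N1CC(n2cnc3c(Cl)nc(Cl)nc32)OCc2ccccc21` gives 467 nM in a functional assay on MDA-MB-231 cells (Homo sapiens) for cytotoxicity, read by sulforhodamine B assay, with a stated time of 3 days; on this read-out lower numbers stand for stronger inhibition and higher numbers for weaker inhibition.
Compound 2 `O=[N+]([O-])c1ccccc1S(=O)(=O)N1CC(n2cnc3c(I)nc(Cl)nc32)OCc2ccccc21` gives 256 nM in this assay.
Compound 3 `O=[N+]([O-])c1ccc(S(=O)(=O)N2C[C@H](n3cnc4c(Cl)nc(Cl)nc43)OCc3ccccc32)cc1` gives 110 nM in this assay.

Among these three numbers, compound 2 holds the second highest. Its nearest neighbour is compound 1, whose number lies higher by an amount that stays within the usual scatter of repeated measurements, so the two cannot be told apart. The furthest is compound 3, whose number is lower by an amount beyond the scatter, so compound 3 does stand apart from compound 2 on this read-out.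

The next compound, compound 4 `O=[N+]([O-])c1ccccc1S(=O)(=O)N1CC(n2cnc3c(Cl)nc(Cl)nc32)OCc2ccccc21`, has not yet been measured in this assay. It differs from compound 2 in one spot: chloro in place of iodo on an aromatic carbon. Everything else in the shared core, including the nitro-bearing sulfonamide side, is kept.

Within the data shown here, no measured pair in this set isolates this same swap, so there is no direct precedent for its size. Given that compounds 1 and 3 carry chloro at that spot and sit in the same broad range as compound 2, the expected step is small, in no clear direction, and likely within the scatter. For compound 4 the estimated value is 300 nM, with a range from 120 nM to 750 nM, which corresponds to an expected 1.2-fold higher number from compound 2 to compound 4 (0.07 log units; within the scatter).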

Compound 4, half-maximal inhibitory concentration: 280 nM
Compound 4: middle estimate off by 1.1-fold (0.03 log units), on the high side; measured number inside the range.
By their numbers in this assay, from the lowest: compound 3; then compounds 2, 4 and 1 (each within the scatter of the next).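

In this assay, chloro in place of iodo on this aromatic carbon next to the ring nitrogen gives a 1.1-fold higher number from compound 2 to compound 4 (0.04 log units; within the scatter) so, with everything else held the same, these two halogens cannot be told apart at this spot. Compound 4 also links to compound 1 through a single change on the sulfonamide side, where nitro in place of amino gives a 1.7-fold lower number from compound 1 to compound 4 (0.22 log units; within the scatter) and again leaves two compounds that this read-out cannot separate. Neither step therefore shows that the group at either spot matters within this small set, and no supporting data are available to explain these results.

Iodo and chloro are the only groups shown on this aromatic carbon, so it remains open whether an amine, a methoxy group or a methyl group there would keep the number in the same range. On the sulfonamide side, only nitro and amino can be compared directly, leaving open what a nitrile or a carboxylic acid at that spot would do.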